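Removing the Benzylidene Arm from the Weakest Thioether

The compounds below may be only part of what the source reports. "The series", "measured", "known", "first", "only" and "open" are said of these compounds alone.

Three compounds share one fused core and differ only at two positions on it. Compound 1 `CCOC(=O)Nc1cc2c(nc(S)n2/N=C/c2ccccc2)c(N)n1` gives 470 nM in a functional assay on L1210 cells (Mus musculus) for inhibition; a higher number here means a weaker inhibitor, a lower number a stronger inhibitor. Compound 3 `CCOC(=O)Nc1cc2c(nc(SCc3ccccc3)n2/N=C/c2ccccc2)c(N)n1` gives 50000 nM in this assay, the highest of the two plain numbers seen so far, reached by a 110-fold higher number from compound 1 to compound 3 (2.03 log units; beyond the scatter). Compound 2 `CCOC(=O)Nc1cc2c(nc(S)n2N)c(N)n1` does not give a number at all; in this assay compound 2 is recorded only as a limit, > 30000 nM.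

Compound 4 `CCOC(=O)Nc1cc2c(nc(SCc3ccccc3)n2N)c(N)n1` has not been measured. It differs from compound 3 by one nitrogen atom in place of a group of 8 heavy atoms (7 carbon, 1 nitrogen; one six-membered aromatic ring of carbon only), on an aromatic nitrogen. Exactly this change has been seen once already, where it produced an at least 63-fold higher number from compound 1 to compound 2 (1.80 log units; beyond the scatter), and that step started from the strongest compound measured. Starting instead from compound 3, which already gives the highest number, a step of similar size in the same direction is therefore expected, a 6.0-fold higher number from compound 3 to compound 4 (0.78 log units; beyond the scatter), most likely carrying the result past the limit of > 30000 nM in this assay, at which 1 of the 3 values shown sits, so that only a limit is reported. Compound 4 is estimated at 300000 nM, within a range from 50000 nM to 3000000 nM.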

Compound 4, half-maximal inhibitory concentration: 600 nM
For compound 4 the middle estimate is 500-fold (2.70 log units) above the measured one; the whole stated range lies above it.
By their numbers in this assay, from the lowest: compounds 1 and 4 (each within the scatter of the next); then compound 3.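

Replacing the benzylidene arm with amino on the ring nitrogen has no fixed effect: with benzylsulfanyl on the core, it gives an 83-fold lower number from compound 3 to compound 4 (1.92 log units; beyond the scatter), the reverse of the step seen with the free sulfur: the same change on two cores in this assay, an at least 63-fold higher number (1.80 log units; beyond the scatter) from compound 1 to compound 2 and an 83-fold lower number (1.92 log units; beyond the scatter) from compound 3 to compound 4, at least 5300-fold (3.72 log units) apart, beyond the scatter of two such steps

Benzyl on the sulfur also reverses its effect: with amino on the ring nitrogen, it gives an at least 50-fold lower number from compound 2 to compound 4 (1.69 log units; beyond the scatter), a step read from a limit of the assay, and the contrast with the benzylidene pair is clear: the same change on two cores in this assay, a 110-fold higher number (2.03 log units; beyond the scatter) from compound 1 to compound 3 and an at least 50-fold lower number (1.69 log units; beyond the scatter) from compound 2 to compound 4, at least 5300-fold (3.72 log units) apart, beyond the scatter of two such steps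

In these four compounds, then, what a change does at one position depends on what the other position carries.

Going by these compounds, whether a methyl or ethyl on the sulfur would act like benzyl remains open. So does whether an acetyl group on the ring nitrogen's amino would act like amino or like the benzylidene arm.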